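The source may hold more compounds than are shown below. What is called first, only, known or untested is meant among the compounds shown, and "the series" means these compounds.

Compound 1 `CC1=CC[C@H]2[C@@H]1CC=C(C)[C@@H](CC[C@H]1[C@]3(C)CC[C@H](OC(=O)c4ccncc4)C(C)(C)O[C@H]3CC[C@@]1(C)O)C2(C)C`: in a functional assay on MCF7 cells (Homo sapiens) for antiproliferative activity, read by MTT assay, with a stated time of 72 h (on this read-out higher numbers stand for weaker inhibition and lower numbers for stronger inhibition), compound 1 gives > 50000 nM, which is a limit of the assay and not a number.
Compound 2 `C=C(C)C(CC[C@@]1(C)C(CC[C@H]2[C@]3(C)CC[C@H](O)C(C)(C)O[C@H]3CC[C@@]2(C)O)=C(C)CC[C@H]1O)OO`: in this assay compound 2 gives 31200 nM.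

Compound 2 thus holds the only number shown, while the other value sits at the limit of > 50000 nM in this assay, at which 1 of the 2 values shown sits. Compound 3 `CC(C)=CCC[C@@]1(C)C(CC[C@H]2[C@]3(C)CC[C@H](O)C(C)(C)O[C@H]3CC[C@@]2(C)O)=C(C)CC[C@H]1O` differs from compound 2 by a group of 4 heavy atoms (4 carbon; no ring) in place of a group of 6 heavy atoms (4 carbon, 2 oxygen; no ring), on a saturated chain carbon, two bonds along the chain from a saturated ring carbon. Going by the values given here, no step between measured compounds is available, so the size of this change cannot be read from a measured pair. Compound 3 is expected to remain weak, with a step of a 1.3-fold higher number from compound 2 to compound 3 (0.11 log units; within the scatter) estimated to lie within or only slightly beyond the scatter. Compound 3 is therefore estimated at 40000 nM, between 15000 nM and 100000 nM.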

Compound 3, half-maximal inhibitory concentration: > 50000 nM
Compound 3 was reported as a limit; the forecaster's own chance of this, stated with the estimate: 40%; middle value at least 1.2-fold (0.09 log units) away from the limit.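

Placing 2-methylprop-1-en-1-yl on this saturated chain carbon, in place of the group of 6 heavy atoms, gives an at least 1.6-fold higher number from compound 2 to compound 3 (0.20 log units; that floor lies within the scatter), the first step readable at this position. As far as these compounds go, because only a floor is available, the true size of the change stays unknown. The value of compound 3 is a limit and not a number, and this change brings no measurable gain in this assay: the limit of > 50000 nM in this assay, at which 2 of the 3 values shown sit.

Still open, from the compounds shown here alone, is whether any group at this place gives a lower number than compound 2. The compounds shown say nothing about an amine, a carboxylic acid or a longer chain there.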